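A methyl on the aromatic nitrogen of compound 1

The compounds below may be only part of what the source reports. "The series", "measured", "known", "first", "only" and "open" are said of these compounds alone.

compound 1 `COc1cc(-c2nnc3c(OC)cc(-c4ccc5[nH]ccc5c4)cn23)cc(OC)c1OC`: 85 nM
compound 2 `COc1cc(-c2nnc3c(OC(C)C)cc(-c4ccc5[nH]ccc5c4)cn23)cc(OC)c1OC`: 261 nM
compound 3 `COc1cc(-c2nnc3c(OC4CC4)cc(-c4ccc5[nH]ccc5c4)cn23)cc(OC)c1OC`: 119 nM

All three compounds were measured in a functional assay on HeLa cells (Homo sapiens) for antiproliferative activity, read by MTT assay, with a stated time of 48 h; a higher number here means a weaker inhibitor, a lower number a stronger inhibitor. Compound 1 gives 85 nM and shares the low end of this small set: the step to its nearest neighbour is a 1.4-fold higher number from compound 1 to compound 3 (0.15 log units; within the scatter), and the step to its furthest is a 3.1-fold higher number from compound 1 to compound 2 (0.49 log units; beyond the scatter). The remaining measured step is a 2.2-fold lower number from compound 2 to compound 3 (0.34 log units; beyond the scatter).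

Compound 4 `COc1cc(-c2nnc3c(OC)cc(-c4ccc5c(ccn5C)c4)cn23)cc(OC)c1OC` differs from compound 1 in one place: methyl in place of hydrogen on an aromatic nitrogen. This is methyl in place of hydrogen on an aromatic nitrogen, turning 1H-indol-5-yl into 1-methyl-1H-indol-5-yl.

Within the data shown here, no measured step touches that nitrogen. All three change the group on an oxygen on an aromatic ring, so they bear on compound 4 only indirectly, as a guide to how large a small change has been among these compounds. The largest of them, a 3.1-fold higher number from compound 1 to compound 2 (0.49 log units; beyond the scatter), is modest. The data give no direction at the nitrogen, but compound 1 already sits at the low end, so in this assay a small rise is expected, quite possibly none beyond the scatter. The expected step is a 1.3-fold higher number from compound 1 to compound 4 (0.11 log units; within the scatter). For compound 4 the estimate is 110 nM, with an expected range of 35 nM to 350 nM.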

Compound 4, half-maximal inhibitory concentration: 15 nM
The estimate for compound 4 lay 7.3-fold (0.87 log units) above the measured number; the measured number lies below the stated range.
By their numbers in this assay, from the lowest: compound 4; then compounds 1 and 3 (each within the scatter of the next); then compound 2.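

In this assay the aromatic nitrogen of the 1H-indol-5-yl group proves to be a position that responds to a small change, and the response runs toward lower numbers: methyl in place of hydrogen gives a 5.7-fold lower number from compound 1 to compound 4 (0.75 log units; beyond the scatter), so the hydrogen on that nitrogen is not needed for compound 4 to reach 15 nM. The changes on the oxygen had shown no such gain, since a 3.1-fold higher number from compound 1 to compound 2 (0.49 log units; beyond the scatter) was a rise beyond the scatter and a 1.4-fold higher number from compound 1 to compound 3 (0.15 log units; within the scatter) stayed within it, which left compound 1 looking like the low end of the set; the nitrogen shows that this low end could still be passed with the addition of a single carbon. Nothing available here explains why the methyl has this effect, and the size of the step is all that can be stated.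

With methyl as the only group shown on this nitrogen, it remains open whether an ethyl group, a longer chain or a chain ending in an amine would hold the number this low or lose the gain. On these data alone, it is also open whether the step would carry over to the isopropyl and cyclopropyl ethers of compound 2 and compound 3.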